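Replacing 1H-pyrazol-1-yl with phenyl on the amide chain

A few compounds are considered here, and "the series" means these few. Any claim that something is new, unique, unknown or untested is made for them only; others in the source may bear on it.

In a physicochemical assay for solubility, read by turbidimetry, measured as kinetic solubility, at pH 6.8 (on this read-out lower numbers stand for lower solubility and higher numbers for higher solubility), compound 2 `COc1ccc(F)cc1N1C(=O)CSC1c1cccc(C(=O)NCCCCn2cccn2)c1` gives 50000 nM. Within the data shown here, this is the highest of the three numbers so far, and it lies beyond the scatter from both of the others. Compound 1 `CC1SC(c2cccc(C(=O)NCCCCc3ccccc3)c2)N(c2ccc(C3CC3)cc2)C1=O` gives 10000 nM, and compound 3 `COc1ccccc1N1C(=O)CSC1c1cc(F)cc(C(=O)NCCCCc2ccccc2)c1` gives 10000 nM, so those two show the same number.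

The next compound is compound 4 `COc1ccc(F)cc1N1C(=O)CSC1c1cccc(C(=O)NCCCCc2ccccc2)c1`, which keeps the core of compound 2 and changes only the chain terminus: phenyl in place of 1H-pyrazol-1-yl on a saturated chain carbon, four bonds along the chain from an amide-type nitrogen. The change is phenyl in place of 1H-pyrazol-1-yl on a saturated chain carbon, four bonds along the chain from an amide-type nitrogen.

Among the measured compounds shown here, no measured pair isolates this change, so any expectation is indirect. Compound 1 and compound 3 both carry phenyl in that place, though both also differ from compound 4 elsewhere in the structure. For the measured compounds named here, their shared number is the only guide, and three compounds are thin ground for it. In this assay, the expected step of a 5.0-fold lower number from compound 2 to compound 4 (0.70 log units; beyond the scatter) is a fall beyond the scatter. For compound 4 the estimated value is 10000 nM, with an expected range of 4000 nM to 25000 nM.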

Compound 4, solubility: 10000 nM
Beside the measured number, compound 4's estimate shows no gap at the digits printed; the measured number falls inside the stated range.
By their numbers in this assay, from the lowest: compounds 1, 3 and 4 (each within the scatter of the next); then compound 2.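

In this assay, phenyl in place of 1H-pyrazol-1-yl on a saturated chain carbon, four bonds along the chain from an amide-type nitrogen, gives a 5.0-fold lower number from compound 2 to compound 4 (0.70 log units; beyond the scatter). Among these compounds, this is the first pair that differs in this one place, so a change at the end of the chain alone, on an otherwise unchanged structure, is now seen to move the read-out beyond the scatter. No measurement shown bears on what lies behind this step.

Going by these compounds, the step rests on a single pair on a single core, so whether it carries over to the core of compound 1 or the core of compound 3 remains open. On these data alone, how the read-out responds to other groups in this place, such as an amine or a carboxylic acid, or to a longer chain, also remains open.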